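Removing the hydroxy group: from compound 2 to compound 3

The compounds below may be only part of what the source reports. "The series", "measured", "known", "first", "only" and "open" are said of these compounds alone.

- Compound 1 `CC(C)c1noc(N2CCC(Oc3cc(N4CCc5cc(N6CCCCC6=O)ccc54)ncn3)CC2)n1`: 3.8
- Compound 2 `CC(C)c1noc(N2CCC(Oc3cc(N4CCc5cc(N6CC(O)CCC6=O)ccc54)ncn3)CC2)n1`: 2.6

In a physicochemical assay for lipophilicity, measured as octanol-water partition, at pH 7.4 (on this read-out higher numbers stand for higher lipophilicity and lower numbers for lower lipophilicity), compound 2 stands lowest of the two measured compounds, at 2.6. Compound 3 `CC(C)c1noc(N2CCC(Oc3cc(N4CCc5cc(N6CCCC6=O)ccc54)ncn3)CC2)n1`, not yet measured, differs from it in one place: 2-oxopyrrolidin-1-yl in place of 5-hydroxy-2-oxopiperidin-1-yl on an aromatic carbon. Here 2-oxopyrrolidin-1-yl replaces 5-hydroxy-2-oxopiperidin-1-yl on an aromatic carbon.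

Going by the values given here, only one measured step bears on this change: a number 1.20 log units lower from compound 1 to compound 2 (beyond the scatter), a large step beyond the scatter, made by putting hydroxy in place of hydrogen on a saturated ring carbon. Compound 3 carries no hydroxy, so much of that step should reverse in this assay. Among the compounds with values here, no measured step shows what a five-membered ring does in place of a six-membered one, so the expected rise is kept smaller. The expected change is a number 0.80 log units higher from compound 2 to compound 3 (beyond the scatter). For compound 3 the estimated value is 3.4, with an expected range of 3 to 3.8.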

Compound 3, distribution coefficient: 3.7
The estimate for compound 3 lay 0.30 log units below the measured number, within the range that was stated.
By their numbers in this assay, from the lowest: compound 2; then compounds 3 and 1 (each within the scatter of the next).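

In this assay, the step with 2-oxopyrrolidin-1-yl in place of 2-oxopiperidin-1-yl is a number 0.10 log units lower from compound 1 to compound 3 (within the scatter), so the five-membered and six-membered rings cannot be told apart here when neither carries a hydroxy. The other step, with 2-oxopyrrolidin-1-yl in place of 5-hydroxy-2-oxopiperidin-1-yl, is a number 1.10 log units higher from compound 2 to compound 3 (beyond the scatter), and it changes both ring size and hydroxy at once, so only the comparison with compound 1 separates the two; of these three compounds, compound 2 alone carries a hydroxy, and it alone stands apart. Nothing available explains why these numbers fall as they do.

On these data alone, it remains open whether a hydroxy on the five-membered ring would give a step of similar size. As far as these compounds go, how an amine or a carboxylic acid on either ring would read in this assay also remains unknown.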